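From cyclopropyl to isopropyl on the ring amide nitrogen

This account rests on a few compounds, and the source may have more. Where it says the series, first, only, none or still open, it means among the compounds named here.

Within the data shown here, only two compounds have numbers so far. In a functional assay on HeLa cells (Homo sapiens) for antiproliferative activity, read by MTT assay, with a stated time of 72 h (a higher number here means a weaker inhibitor, a lower number a stronger inhibitor), compound 1 (`CC(C)N1C(=O)COc2ccc(-c3cnc(Cl)c(NS(=O)(=O)c4ccc(F)cc4)c3)cc21`) gives 5380 nM and compound 2 (`COc1ncc(-c2ccc3c(c2)N(C2CC2)C(=O)CO3)cc1NS(=O)(=O)c1ccc(F)cc1`) gives 6030 nM. Compound 2 therefore stands level with compound 1, as the two values lie within the scatter of each other. Neither value can be ranked above the other.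

The next compound is compound 3 (`COc1ncc(-c2ccc3c(c2)N(C(C)C)C(=O)CO3)cc1NS(=O)(=O)c1ccc(F)cc1`), not yet measured. Relative to compound 2, it carries isopropyl in place of cyclopropyl on an amide-type nitrogen in a ring. Among the measured compounds shown here, no measured step tests this exchange, so the expectation has little to rest on. In this assay, no change beyond the scatter is expected, and neither direction is clearly favoured. The estimated step is a 1.2-fold lower number from compound 2 to compound 3 (0.08 log units; within the scatter). For the measured compounds named here, the starting point for this expectation is compound 2 at 6030 nM, and the range is kept wide since no direct precedent exists. Compound 3 is estimated at 5000 nM, with an expected range from 2000 nM to 12000 nM.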

Compound 3, half-maximal inhibitory concentration: 2790 nM
Beside the measured number, compound 3's estimate is 1.8-fold (0.25 log units) above it; the range from low to high includes it.
By their numbers in this assay, from the lowest: compounds 3, 1 and 2 (each within the scatter of the next, the first and the last beyond it).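

Cyclopropyl and isopropyl have the same count of heavy atoms on the amide-type nitrogen in a ring, yet in this assay the exchange gives a 2.2-fold lower number from compound 2 to compound 3 (0.33 log units; beyond the scatter) and is the first step in the series to pass beyond the scatter, though only modestly. This position therefore does not treat the ringed and ring-free groups as equivalent, at least with methoxy on the aromatic carbon. With isopropyl held on that nitrogen, methoxy in place of chloro gives a 1.9-fold lower number from compound 1 to compound 3 (0.29 log units; within the scatter) and stays within the scatter, so this pair shows no difference that can be read between those two groups, and nothing on hand accounts for either step.

As far as these compounds go, the exchange on the nitrogen is seen in a single pair, so it remains open whether the same step appears with chloro on the aromatic carbon. Also open, from the compounds shown here alone, is how a longer chain such as n-butyl on that nitrogen, or an amine in place of methoxy on the aromatic carbon, would read in this assay against these compounds.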